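The source may hold more compounds than are shown below. What is called first, only, known or untested is meant among the compounds shown, and "the series" means these compounds.

Measured so far in a functional assay on A549 cells (Homo sapiens) for antiproliferative activity, read by MTT assay, with a stated time of 72 h; a higher number here means a weaker inhibitor, a lower number a stronger inhibitor:
- compound 1 `NC(=S)N1N=C(c2ccc(N3CCCCC3)cc2)CC1c1ccc(Cl)cc1`: 33800 nM
- compound 3 `Clc1ccc(C2CC(c3ccc(N4CCCCC4)cc3)=NN2c2nc(-c3ccc(Br)cc3)cs2)cc1`: 39700 nM
- compound 2 `O=[N+]([O-])c1ccc(-c2csc(N3N=C(c4ccc(N5CCCCC5)cc4)CC3c3ccc(Cl)cc3)n2)cc1`: reported only as a limit, > 100000 nM

Where compound 3 stands: among the numbers in hand, compound 3 sits together with compound 1, the step of a 1.2-fold higher number from compound 1 to compound 3 (0.07 log units; within the scatter) lying within the scatter, so neither is set apart from the other. The limit for compound 2 is the ceiling of this assay the limit of > 100000 nM in this assay, at which 1 of the 3 values shown sits, and gives no number to rank.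

The next compound, compound 4 `COc1ccc(-c2csc(N3N=C(c4ccc(N5CCCCC5)cc4)CC3c3ccc(Cl)cc3)n2)cc1`, differs from compound 3 by methoxy in place of bromo on an aromatic carbon.

For the measured compounds named here, two measured steps touch this position or its neighbourhood. The exchange at the same aromatic carbon, an at least 2.5-fold lower number from compound 2 to compound 3 (0.40 log units; beyond the scatter), shows that the group on this ring can move the number beyond the scatter. The exchange on the ring nitrogen, a 1.2-fold higher number from compound 1 to compound 3 (0.07 log units; within the scatter), left the number in place. Going by the values given here, no measured step puts methoxy at this carbon, so the direction is open. The step expected for compound 4 is a 1.0-fold higher number from compound 3 to compound 4 (0.00 log units; within the scatter), not beyond the scatter in either direction. Compound 4 is estimated at 40000 nM, between 15000 nM and 100000 nM.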

Compound 4, half-maximal inhibitory concentration: > 100000 nM
Compound 4: no number, only a limit; the forecaster's own chance of this, stated with the estimate: 25%; middle value at least 2.5-fold (0.39 log units) away from the limit.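

In this assay, the change from 4-bromophenyl to 4-methoxyphenyl gives an at least 2.5-fold higher number from compound 3 to compound 4 (0.40 log units; beyond the scatter), so a step beyond the scatter at this carbon now also appears with a group other than nitro. Compound 4 is reported only as a limit, the same one that compound 2 carries: the limit of > 100000 nM in this assay, at which 2 of the 4 values shown sit.

Of the three groups at this carbon, only bromo gives a number, and the step between the nitro and methoxy compounds cannot be read. Whether any group here gives a lower number than compound 3 remains open, as the compounds shown include no such case. An amine, a hydroxyl or a carboxylic acid at this carbon, or the plain phenyl ring with hydrogen there, would show whether bromo is unusual in giving a number.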